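Swapping the Aryl Group in a Quinolinol Series

The compounds below may be only part of what the source reports. "The series", "measured", "known", "first", "only" and "open" are said of these compounds alone.

Measured so far:
- compound 1, `Cc1ccnc(NC(c2ccc3cccnc3c2O)c2c(Cl)cccc2Cl)c1`: 7200 nM
- compound 2, `Cc1cc(C)c(C(Nc2ccccn2)c2ccc3cccnc3c2O)c(C)c1`: 10000 nM

In a functional assay on U-87MG ATCC cells for inhibition, with U-87 MG (Homo sapiens) as the target, read by MTT assay, with a stated time of 72 h (on this read-out lower numbers stand for stronger inhibition and higher numbers for weaker inhibition), compound 1 gives 7200 nM. In this assay compound 2 gives 10000 nM. Among the measured compounds shown here, of these two numbers, the one for compound 2 is the larger, but its gap to compound 1 lies within the scatter, so the two compounds cannot be told apart on this read-out; both sit in the weak range.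

Compound 3, `Oc1c(C(Nc2ccccn2)c2ccccc2F)ccc2cccnc12`, has not yet been measured in this assay. It keeps the shared core of compound 2 and differs in one place: 2-fluorophenyl in place of 2,4,6-trimethylphenyl on a saturated chain carbon bound to an aromatic carbon and a nitrogen on an aromatic ring. The group that leaves is the larger one, and the group that enters carries a fluorine in place of the three methyl groups.

For the measured compounds named here, no pair of measured compounds differs in exactly one place, so there is no measured step to lean on. The two numbers at hand both point to weak inhibition, and there is nothing to suggest the change moves the number far in either direction. The step from compound 2 to compound 3 is therefore expected to be small, a 1.1-fold lower number from compound 2 to compound 3 (0.05 log units; within the scatter), not beyond the scatter. Compound 3 is expected to give about 9000 nM in this assay, within a range from 3000 nM to 30000 nM.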

Compound 3, half-maximal inhibitory concentration: > 10000 nM
Compound 3 ended at the assay's limit; the forecaster's own chance of this, stated with the estimate: 25%; middle value at least 1.1-fold (0.04 log units) away from the limit.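

In this assay compound 3 gives > 10000 nM, which is a limit of the assay and not a number. This shows that, on a saturated chain carbon bound to an aromatic carbon and a nitrogen on an aromatic ring, putting 2-fluorophenyl in place of 2,4,6-trimethylphenyl brings a number no lower from compound 2 to compound 3 (the limit leaves the size open) and so the smaller aryl group with its single fluorine gives no gain in inhibition on this read-out. The size of the step from compound 2 to compound 3 cannot be read, because the value of compound 3 stops at a limit: the limit of > 10000 nM in this assay, at which 1 of the 3 values shown sits.

On these data alone, whether compound 3 truly inhibits less than compound 2, or about the same, stays open, since a limit cannot settle that. Also open is whether any other group at this place would give a clearly lower number, for example a phenyl ring carrying an amine or a carboxylic acid, or a longer chain in place of the aryl ring, since every compound shown carries a plain substituted phenyl ring there.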